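Swapping amino for methyl on a nitro-sulfonyl naphthyridine core

The source may hold more compounds than are shown below. What is called first, only, known or untested is meant among the compounds shown, and "the series" means these compounds.

Measured so far:
compound 1 `Nc1cc(S(=O)(=O)c2ccccc2)c([N+](=O)[O-])c2cccnc12`: 297 nM
compound 2 `CS(=O)(=O)c1cc(N)c2ncccc2c1[N+](=O)[O-]`: > 10000 nM

For the measured compounds named here, in an assay for binding affinity to Neuropeptide Y receptor type 1 (Homo sapiens), read by radioligand binding (on this read-out higher numbers stand for weaker inhibition and lower numbers for stronger inhibition), compound 1 gives 297 nM, the only plain number among the two results. For compound 2 the result of > 10000 nM is a limit of the assay, not a number (the limit of > 10000 nM in this assay, at which 1 of the 2 values shown sits). Going by the values given here, the one measured step, an at least 33-fold higher number from compound 1 to compound 2 (1.52 log units; beyond the scatter), concerns methyl in place of phenyl on a sulfonyl sulfur and does not touch the change now in question. Compound 3 `Cc1cc(S(=O)(=O)c2ccccc2)c([N+](=O)[O-])c2cccnc12` differs from compound 1 by methyl in place of amino on an aromatic carbon. Among the compounds with values here, no measured step bears on this change. Compound 3 is expected to give about 800 nM in this assay, within 150 nM to 5000 nM, a step of a 2.7-fold higher number from compound 1 to compound 3 (0.43 log units; beyond the scatter) that is an estimate only.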

Compound 3, inhibition constant: > 10000 nM
Compound 3: only a limit was reported (the forecaster's own chance of this, stated with the estimate: 10%); at least 12-fold (1.09 log units) between middle value and limit.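

On this aromatic carbon, para to a nitro group, the amino group of compound 1 matters: in this assay, methyl in its place gives an at least 33-fold higher number from compound 1 to compound 3 (1.52 log units; beyond the scatter). Going by these compounds, compound 3 gives > 10000 nM, which is a limit of the assay and not a number, so the true size of this step stays unknown. The sulfonyl sulfur is no longer the only place where a single change reaches this limit: the limit of > 10000 nM in this assay, at which 2 of the 3 values shown sit.

On these data alone, whether a hydroxyl or a dimethylamino group on this carbon would keep a result near that of compound 1 remains open.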